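Methyl to sec-butyl on the imine nitrogen

The source may hold more compounds than are shown below. What is called first, only, known or untested is meant among the compounds shown, and "the series" means these compounds.

Compound 3 `C/N=c1\c(O)c(O)\c1=N/Cc1ccc(C#N)cc1` carries a methyl on the double-bonded nitrogen. In a functional assay for inhibition, with Rattus norvegicus as the target (a lower number here means a stronger inhibitor, a higher number a weaker inhibitor), compound 3 reaches only the limit > 30000 nM, so it stands at the weak end of the numbers shown without a readable value. Compound 1 `CCCC/N=c1\c(O)c(O)\c1=N/Cc1ccc(C#N)cc1`, the propyl analogue, also sits at the limit > 30000 nM in this assay. Compound 2 `CCC(C)(C)/N=c1\c(O)c(O)\c1=N/Cc1c(C)cc(C#N)cc1Cl`, with a branched chain on that nitrogen and a differently substituted benzyl, gives 160 nM in this assay.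

The step to compound 4 `CC[C@@H](C)/N=c1\c(O)c(O)\c1=N/Cc1ccc(C#N)cc1` is sec-butyl in place of methyl on a double-bonded nitrogen. Within the data shown here, the one measured step on this position, a step that the two limits leave unreadable from compound 1 to compound 3, is unreadable because both ends sit on (the limit of > 30000 nM in this assay, at which 2 of the 3 values shown sit), so it gives no size for a chain change here. Among the measured compounds shown here, compound 2 shows that a branched chain on this nitrogen can go with a strong value, but its benzyl differs as well, so no step connects it to compound 3.

For compound 4 the expectation is an improvement over the limit of compound 3 that stays uncertain, expressed as an at least 3.0-fold lower number from compound 3 to compound 4 (0.47 log units; beyond the scatter). Compound 4 is therefore estimated at 10000 nM, within 1500 nM to 40000 nM, with a real chance that this assay again reports only a limit.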

Compound 4, half-maximal inhibitory concentration: 4000 nM
The estimate for compound 4 lay 2.5-fold (0.40 log units) above the measured number; low and high end bracket the measured number.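

On the double-bonded nitrogen, a chain change now gives a readable step in this assay: sec-butyl in place of methyl gives an at least 7.5-fold lower number from compound 3 to compound 4 (0.87 log units; beyond the scatter), beyond the scatter. Sec-butyl in place of butyl on the same nitrogen gives an at least 7.5-fold lower number from compound 1 to compound 4 (0.87 log units; beyond the scatter), so with the rest of the structure unchanged, the branched chain gives a measurable value where both unbranched chains shown do not. Both sizes are lower bounds, not full step sizes, because compound 1 and compound 3 each enter as a limit of the assay: the limit of > 30000 nM in this assay, at which 2 of the 4 values shown sit.

Among these compounds, the step between the two unbranched chains cannot be read, and no step separates the contribution of the chain on this nitrogen from that of the benzyl substituents in compound 2. Also open, going by these compounds, is how the opposite configuration at the sec-butyl stereocentre, or a cyclohexyl group or a longer branched chain on this nitrogen, would read in this assay with the benzyl of compound 4 kept in place.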